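This account rests on a few compounds, and the source may have more. Where it says the series, first, only, none or still open, it means among the compounds named here.

Measured in an assay on isolated protein for inhibition of aldehyde dehydrogenase 1A1 (Homo sapiens), read by spectrophotometry, tested at 10 uM; on this read-out lower numbers stand for less inhibition and higher numbers for more inhibition at the one concentration tested (going by the name of the read-out):
compound 1, `Cc1cccc(Cn2c(CN3CCN(C(=O)C4CCCC4)CC3)nc3ccccc32)c1`, gives 67.5%
compound 2, `Cc1cccc(Cn2c(CN3CCN(C(=O)CC(C)C)CC3)nc3ccccc32)c1`, gives 71.4%
compound 3, `Cc1cccc(Cn2c(CN3CCN(C(=O)c4cccs4)CC3)nc3ccccc32)c1`, gives 60.8%

Compound 3 stands lowest of the three numbers, though only its gap to compound 2 is beyond the scatter; its gap to compound 1 is within it. Compound 4, `CCCC(=O)N1CCN(Cc2nc3ccccc3n2Cc2cccc(C)c2)CC1`, differs from compound 3 by propyl in place of thiophen-2-yl on a carbonyl carbon. Both earlier steps onto this carbonyl carbon bear on the change: a number 6.7 percentage points lower from compound 1 to compound 3 (within the scatter) and a number 10.6 percentage points lower from compound 2 to compound 3 (beyond the scatter), each exchanging cyclopentyl or isobutyl for thiophen-2-yl and each moving the number down, one within and one modestly beyond the scatter. Compound 4 runs the opposite way, from thiophen-2-yl to propyl, so a modest rise in this assay is expected, about a number 7.2 percentage points higher from compound 3 to compound 4 (within the scatter). Compound 4 is therefore estimated at 68%, ranging from 58% to 78%.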

Compound 4, a percentage reported as inhibition, at one concentration (the size of the read-out at that concentration, not a potency): 79.1%
Compound 4: the middle estimate sits 11.1 percentage points below what was measured, outside the stated range (above it).
By their numbers in this assay, from the lowest: compounds 3, 1, 2 and 4 (each within the scatter of the next, the first and the last beyond it).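

In this assay, propyl on the carbonyl carbon stands clearly apart from thiophen-2-yl (a number 18.3 percentage points higher from compound 3 to compound 4 (beyond the scatter)). It also separates from cyclopentyl (a number 11.6 percentage points higher from compound 1 to compound 4 (beyond the scatter)), which isobutyl did not do, while the loss of the isobutyl branch methyl cannot be read (a number 7.7 percentage points higher from compound 2 to compound 4 (within the scatter)). Nothing available explains why these groups differ.

Going by these compounds, whether a longer straight chain such as pentyl, or an amine on the carbonyl carbon, would hold this level remains open. Readings at a single concentration also leave relative potency open.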